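Swapping an aryl group on a shared cytotoxic core

A few compounds are considered here, and "the series" means these few. Any claim that something is new, unique, unknown or untested is made for them only; others in the source may bear on it.

Compound 1 `O=C1C(O)=C(C(c2ccc(F)cc2)c2c[nH]c3ccccc23)C(=O)c2ccccc21` gives 65200 nM in a toxicity assay (Homo sapiens) for cytotoxicity, read by MTT assay, with a stated time of 48 h (on this read-out lower numbers stand for stronger inhibition and higher numbers for weaker inhibition), the highest of the two numbers shown; the nearest is compound 2 `Cc1[nH]c2ccccc2c1C(C1=C(O)C(=O)c2ccccc2C1=O)c1ccc([N+](=O)[O-])cc1`, which gives 15100 nM in this assay, a gap beyond the scatter. Compound 3 `O=C1C(O)=C(C(c2cccs2)c2c[nH]c3ccccc23)C(=O)c2ccccc21` differs from compound 1 only by thiophen-2-yl in place of 4-fluorophenyl on a saturated chain carbon bound to an aromatic carbon and a double-bonded ring carbon. Among the measured compounds shown here, no measured pair shows this exact change, so the expected step is small, in either direction, and may not exceed the scatter; the estimated step is a 1.3-fold lower number from compound 1 to compound 3 (0.12 log units; within the scatter). Compound 3 is therefore expected to give about 50000 nM in this assay, within a range from 20000 nM to 130000 nM.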

Compound 3, half-maximal inhibitory concentration: 31300 nM
Compound 3: the middle estimate sits 1.6-fold (0.20 log units) above what was measured; low and high end bracket the measured number.
By their numbers in this assay, from the lowest: compound 2; then compound 3; then compound 1.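

At the saturated chain carbon bound to an aromatic carbon and a double-bonded ring carbon, the aryl group does register in this assay: thiophen-2-yl in place of 4-fluorophenyl gives a 2.1-fold lower number from compound 1 to compound 3 (0.32 log units; beyond the scatter), a modest step. Among the compounds shown here, compound 1 and compound 2 differ in more than one place, so this is the first comparison that isolates this position. Nothing shown accounts for the step. From the compounds shown here alone, whether a pyridine ring or a plain methyl group at this carbon would move the number further remains open.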